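The source may report more compounds than this note shows. Statements on the series, on what has been measured and on what is new or still open speak of the compounds shown alone.

Measured compounds and their values in a functional assay on A549 cells (Homo sapiens) for cytotoxicity, read by MTT assay, with a stated time of 48 h; a higher number here means a weaker inhibitor, a lower number a stronger inhibitor:

Compound 1, `COc1cc(-c2nnc3n2NC(c2ccco2)C(C(=O)c2cccs2)S3)cc(OC)c1OC`: 78700 nM

Compound 2, `COc1cc(-c2nnc3n2NC(c2ccco2)C(C(=O)c2ccc(F)cc2)S3)cc(OC)c1OC`: 53700 nM

Compound 3, `COc1cc(-c2nnc3n2NC(c2cccs2)C(C(=O)c2ccccc2)S3)cc(OC)c1OC`: 69400 nM

Among these three, compound 3 gives the second highest number in this assay. Its nearest neighbour is compound 1, and the gap between them lies within the scatter; its furthest neighbour is compound 2, and that gap also lies within the scatter. In plain terms, the three measured compounds cannot be told apart by these numbers.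

Compound 4, `COc1cc(C(=O)C2Sc3nnc(-c4cc(OC)c(OC)c(OC)c4)n3NC2c2cccs2)cc(OC)c1OC`, has not yet been measured. It differs from compound 3 in one place: 3,4,5-trimethoxyphenyl in place of phenyl on a carbonyl carbon. Among the measured compounds shown here, one measured step touches the same place, the group on the carbonyl carbon: a 1.5-fold lower number from compound 1 to compound 2 (0.17 log units; within the scatter). That step stayed within the scatter, so a change of the group on the carbonyl carbon has so far left the numbers in this assay essentially where they were. For the measured compounds named here, only one such step is available, and no measured compound carries the 3,4,5-trimethoxyphenyl group on the carbonyl carbon, so the expectation rests on thin ground. On this basis the expected step from compound 3 to compound 4 is a 1.0-fold higher number from compound 3 to compound 4 (0.00 log units; within the scatter), that is, no movement beyond the scatter. The estimated value for compound 4 in this assay is 70000 nM, with a range from 30000 nM to 160000 nM.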

Compound 4, half-maximal inhibitory concentration: > 100000 nM
Compound 4: only a limit was reported (the forecaster's own chance of this, stated with the estimate: 10%); middle value at least 1.4-fold (0.15 log units) from the limit.
By their numbers in this assay, from the lowest: compounds 2, 3 and 1 (each within the scatter of the next). At a limit, above all of these: compound 4.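

Compound 4 is the first compound shown with oxygen atoms in the group on the carbonyl carbon: 3,4,5-trimethoxyphenyl brings 12 heavy atoms where phenyl has 6, and 3 hydrogen-bond acceptors where phenyl has 0. In this assay this change gives an at least 1.4-fold higher number from compound 3 to compound 4 (0.15 log units; that floor lies within the scatter), so the larger group brings no lower number, yet the printed floor of the step does not establish a real rise. The reading for compound 4 is a limit and not a number, which leaves the true size of the step unknown: the limit of > 100000 nM in this assay, at which 1 of the 4 values shown sits.

The compounds shown leave open whether an amine or a carboxylic acid on the phenyl ring would shift the number beyond the scatter. Also open, going by these compounds, is what a short alkyl chain on the carbonyl carbon, with no aromatic ring there, would do.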